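Benzyl for cyclohexyl on the amide nitrogen of compound 3

The compounds below may be only part of what the source reports. "The series", "measured", "known", "first", "only" and "open" are said of these compounds alone.

Compound 3 `CCC(C)C(NC(=O)n1nnc2ccccc21)C(=O)NC1CCCCC1` was tested in a functional assay on HEL cells (Homo sapiens) for cytotoxicity (on this read-out lower numbers stand for higher toxicity in this test and higher numbers for lower toxicity in this test), and gave 76 ug/mL. Among the two numbers reported it is the highest; the nearest is compound 2 `CCC(C)C(NC(=O)n1nnc2ccccc21)C(=O)NC(c1ccccc1)c1ccccc1`, which gave 40 ug/mL, and the gap between the two lies within the scatter of the test, so neither can be called less toxic than the other. Compound 1 `CCC(C)C1NC(=O)N(C2CCCC2)C1=O` gave > 50 ug/mL, which is a limit of the test rather than a number.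

Compound 4 `CCC(C)C(NC(=O)n1nnc2ccccc21)C(=O)NCc1ccccc1` differs from compound 3 in one place: benzyl in place of cyclohexyl on an amide-type nitrogen. Going by the values given here, no measured pair in this set shows what such a swap does in this test. The two groups are of similar size and the set gives no sign that either makes these compounds more toxic, so the step from compound 3 to compound 4 is expected to stay within the scatter, with no change beyond it, estimated as a 1.1-fold lower number from compound 3 to compound 4 (0.04 log units; within the scatter). Compound 4 is therefore expected to give about 70 ug/mL, within a range from 35 ug/mL to 150 ug/mL.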

Compound 4, half-maximal cytotoxic concentration: 156 ug/mL
Beside the measured number, compound 4's estimate is 2.2-fold (0.35 log units) below it; measured number outside the range, above it.
By their numbers in this assay, from the lowest: compounds 2 and 3 (each within the scatter of the next); then compound 4.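

On the amide-type nitrogen, this assay now shows that this position is not silent: benzyl in place of cyclohexyl gives a 2.1-fold higher number from compound 3 to compound 4 (0.31 log units; beyond the scatter), a modest step that only just clears the scatter. Taking one phenyl off the saturated chain carbon bound to that nitrogen, leaving hydrogen in its place, gives a larger step, a 3.9-fold higher number from compound 2 to compound 4 (0.59 log units; beyond the scatter), and both steps point the same way, towards lower toxicity in this test for the smaller benzyl group. Nothing measured here offers a reason for either step.

The compounds shown leave open what a longer chain in place of benzyl, or a benzyl carrying an amine or a carboxylic acid, would do to this number. Going by these compounds, whether the step from cyclohexyl to benzyl holds on another core also stays open.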